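Methoxy to hydroxy on two stilbene-like cores

A few compounds are considered here, and "the series" means these few. Any claim that something is new, unique, unknown or untested is made for them only; others in the source may bear on it.

Measured so far in a functional assay on MCF7 cells (Homo sapiens) for cytotoxicity, read by MTT assay, with a stated time of 72 h; a higher number here means a weaker inhibitor, a lower number a stronger inhibitor:
- compound 1 `Cc1cc(/C=C/c2ccc(O)cc2)[nH]n1`: 48100 nM
- compound 2 `COc1ccc(/C=C/c2cc(C)n[nH]2)cc1`: 9700 nM
- compound 3 `COc1ccc(/C=C/c2cc(C)no2)cc1`: > 100000 nM, a limit of the assay, not a number

Compound 2 and compound 1 share a core and differ by hydrogen in place of methyl on an oxygen on an aromatic ring; that step is a 5.0-fold higher number from compound 2 to compound 1 (0.70 log units; beyond the scatter). Compound 3 carries a different core; how the two cores differ is not broken down here. Its value sits at the limit of > 100000 nM in this assay, at which 1 of the 3 values shown sits. Compound 4 `Cc1cc(/C=C/c2ccc(O)cc2)on1` stands to compound 3 exactly as compound 1 stands to compound 2, the same change at the same place: hydrogen in place of methyl on an oxygen on an aromatic ring. Since the earlier step in this assay raised the number, the number for compound 4 is expected to move in the same direction, roughly a step that the limit leaves unreadable from compound 3 to compound 4, though it starts from a limit. The estimate for compound 4 is 300000 nM, between 100000 nM and 1000000 nM, most likely reported again only as a limit.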

Compound 4, half-maximal inhibitory concentration: 50200 nM
Beside the measured number, compound 4's estimate is 6.0-fold (0.78 log units) above it; measured number below the stated range.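

In this assay, putting hydrogen in place of methyl on the oxygen gives an at least 1.9-fold lower number from compound 3 to compound 4 (0.29 log units; that floor lies within the scatter), so this change cannot be assumed to carry over from one core to the other. Set beside the earlier step, the new one does not match it: the same change on two cores in this assay, a 5.0-fold higher number (0.70 log units; beyond the scatter) from compound 2 to compound 1 and an at least 1.9-fold lower number (0.29 log units; that floor lies within the scatter) from compound 3 to compound 4, at least 9.8-fold (0.99 log units) apart, beyond the scatter of two such steps Compound 3 reads > 100000 nM, a limit of the assay and not a number, so the true size of the new step stays unknown, and these data do not show why the cores differ.

As far as these compounds go, it remains open how an amine or a longer chain such as ethoxy in place of the hydroxy would behave on each core. From the compounds shown here alone, whether the mismatch extends to any core beyond these two also remains open.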